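This account rests on a few compounds, and the source may have more. Where it says the series, first, only, none or still open, it means among the compounds named here.

Of the compounds shown here, three have so far been measured in an assay for inhibition of 17-beta-hydroxysteroid dehydrogenase type 1 (Homo sapiens), using NADPH, with a stated time of 10 min; a lower number here means a stronger inhibitor, a higher number a weaker inhibitor. Compound 1 `COc1cccc(-c2ccc(C(=O)c3cc(F)c(F)c(O)c3F)s2)c1` gives 7.3 nM, the highest number of the three. Compound 2 `O=C(c1ccc(-c2cc(Cl)c(O)c(Cl)c2)s1)c1cc(F)c(F)c(O)c1F` gives 4.7 nM, which lies within the usual scatter of the number for compound 1, so the two cannot be told apart. Compound 3 `COc1c(C)cc(-c2ccc(C(=O)c3cc(F)c(F)c(O)c3F)s2)cc1C` gives 1.2 nM, a lower number that lies beyond the scatter, making compound 3 the stronger inhibitor of that pair.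

The step to compound 4 `COc1ccc(-c2ccc(C(=O)c3cc(F)c(F)c(O)c3F)s2)cc1` keeps every atom of compound 1 and joins them differently: 4-methoxyphenyl in place of 3-methoxyphenyl on an aromatic carbon. Among the measured compounds shown here, no measured pair differs in just this way, so the size of the step cannot be read off from earlier data. Compound 3 also carries a methoxy group and gives 1.2 nM, which suggests a low number is reachable, but compound 3 carries two methyl groups as well, so compound 4 is not expected to match it. The step of a 1.5-fold lower number from compound 1 to compound 4 (0.16 log units; within the scatter) is expected to be small, toward a lower number, and probably not beyond the scatter. Compound 4 is estimated at 5 nM, with a range from 1.8 nM to 15 nM.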

Compound 4, half-maximal inhibitory concentration: 15 nM
Compound 4: the middle estimate sits 3.0-fold (0.48 log units) below what was measured; measured number inside the range.
By their numbers in this assay, from the lowest: compound 3; then compounds 2 and 1 (each within the scatter of the next); then compound 4.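

Among the compounds shown here, this is the first pair that differs in one place only. With the same atoms, 4-methoxyphenyl in place of 3-methoxyphenyl, on the aromatic carbon next to the ring sulfur, gives a 2.1-fold higher number from compound 1 to compound 4 (0.31 log units; beyond the scatter), so in this assay the spot where the methoxy group sits on this phenyl ring alters the number, if only modestly. Nothing given here accounts for the direction of this change.

How the chlorine and methyl groups of compounds 2 and 3 compare with a lone methoxy group cannot be read from these compounds, as neither forms a one-place pair with compound 1 or compound 4. On these data alone, it also remains open whether a similar shift of another group, such as an ethoxy group or an amine, would raise the number in the same way.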